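The source may report more compounds than this note shows. Statements on the series, on what has been measured and on what is new or still open speak of the compounds shown alone.

Measured in a functional assay on SK-OV-3 cells (Homo sapiens) for inhibition, read by sulforhodamine B assay, with a stated time of 48 h; on this read-out higher numbers stand for weaker inhibition of growth and lower numbers for stronger inhibition of growth:
- compound 1 `CCCCCCCCCCCC[C@@H](O)[C@H]1CC[C@H]([C@H](O)CCCCCCCCCCN(C)C(=O)c2ccnn2C)O1`: 15800 nM
- compound 2 `CCCCCCCCCCCC[C@@H](O)[C@H]1CC[C@H]([C@H](O)CCCCCCCCCCNCc2ccnn2C)O1`: 2090 nM
- compound 3 `CCCCCCCCCCCC[C@@H](O)[C@H]1CC[C@H]([C@H](O)CCCCCCCCCCC(=O)Nc2ccnn2C)O1`: 100000 nM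

Of the three, compound 3 has the highest number, 100000 nM, and so shows the weakest growth inhibition. Compound 4 `CCCCCCCCCCCC[C@@H](O)[C@H]1CC[C@H]([C@H](O)CCCCCCCCCCOC(=O)c2ccnn2C)O1` differs from compound 3 in one place: ((1-methyl-1H-pyrazol-5-yl)carbonyl)oxy in place of (1-methyl-1H-pyrazol-5-yl)carbamoyl on a saturated chain carbon, ten or more bonds along the chain from an oxygen on a saturated carbon and a saturated ring carbon.

This exact exchange has not been measured, so the other steps at this place on the chain bear on it only indirectly. The modest 6.3-fold higher number from compound 1 to compound 3 (0.80 log units; beyond the scatter) and the large 48-fold higher number from compound 2 to compound 3 (1.68 log units; beyond the scatter) show that changing this group can move the number well beyond the scatter. Compound 1, at 15800 nM, carries a (1-methyl-1H-pyrazol-5-yl)carbonyl unit, as compound 4 does, so a modest move towards compound 1 seems most likely in this assay. The expected change is a 3.3-fold lower number from compound 3 to compound 4 (0.52 log units; beyond the scatter), towards a lower number. For compound 4 the estimated value is 30000 nM, with an expected range from 8000 nM to 100000 nM.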

Compound 4, concentration for 50% growth inhibition: 100000 nM
For compound 4 the middle estimate is 3.3-fold (0.52 log units) below the measured one, and the stated range covers the measured number.
By their numbers in this assay, from the lowest: compound 2; then compound 1; then compounds 3 and 4 (each within the scatter of the next).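

In this assay, exchanging the (1-methyl-1H-pyrazol-5-yl)carbamoyl group for ((1-methyl-1H-pyrazol-5-yl)carbonyl)oxy removes the amide hydrogen and leaves the read-out untouched (no change at the digits printed from compound 3 to compound 4 (within the scatter)). Sharing the (1-methyl-1H-pyrazol-5-yl)carbonyl unit with compound 1 does not bring compound 4 to the level of that compound (a 6.3-fold higher number from compound 1 to compound 4 (0.80 log units; beyond the scatter)), and the ((1-methyl-1H-pyrazol-5-yl)methyl)amino group of compound 2 remains far apart from this ester (a 48-fold higher number from compound 2 to compound 4 (1.68 log units; beyond the scatter)). No measurement available here accounts for these differences.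

The compounds shown leave open whether the lower number of compound 2 depends on its amine nitrogen or on the methylene joining that nitrogen to the pyrazole. An ether or a tertiary amine at this place on the chain would bear on that question.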